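The source may hold more compounds than are shown below. What is called first, only, known or untested is meant among the compounds shown, and "the series" means these compounds.

Of the compounds shown here, three have so far been measured in a functional assay on THP-1 cells (Homo sapiens) for inhibition, read by sulforhodamine B assay, with a stated time of 48 h, tested at 50 uM; a lower number here means less inhibition of growth, a higher number more inhibition of growth at the concentration tested. Compound 1 `COc1ccc(/C=C/C(=O)/C=C/c2ccc(OCc3cn(CCCCOc4cc(=O)oc5ccccc45)nn3)c(OC)c2)cc1OC` gives 59%, compound 3 `COc1ccc(/C=C/C(=O)/C=C/c2ccc(OCc3cn(CCCOc4cc(=O)oc5ccccc45)nn3)c(OC)c2)cc1OC` gives 73%, and compound 2 `COc1cc(/C=C/C(=O)/C=C/c2cc(OC)c(OC)c(OC)c2)ccc1OCc1cn(CCOc2cc(=O)oc3ccccc23)nn1` gives 99%. Compound 2 therefore holds the highest of the three numbers, and its gaps to both of the others lie beyond the scatter.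

Compound 4 `COc1ccc(/C=C/C(=O)/C=C/c2ccc(OCc3cn(CCOc4cc(=O)oc5ccccc45)nn3)c(OC)c2)cc1` has not yet been tested. It departs from compound 2 at a single place, with 4-methoxyphenyl in place of 3,4,5-trimethoxyphenyl on a double-bonded chain carbon bound to a double-bonded chain carbon.

For the measured compounds named here, no measured pair isolates this change, so its size in this assay cannot be read directly and the expectation remains loose. With compound 2 at 99% there is little room for a rise, and compound 3 at 73% shows how far a relative of it can stand lower. The estimated step is a number 21 percentage points lower from compound 2 to compound 4 (beyond the scatter), an expected fall beyond the scatter. For compound 4 the estimated value is 78%, with an expected range of 52% to 99%.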

Compound 4, percent growth inhibition at one concentration: 78%
Beside the measured number, compound 4's estimate shows no gap at the digits printed, and the stated range covers the measured number.
By their numbers in this assay, from the lowest: compound 1; then compounds 3 and 4 (each within the scatter of the next); then compound 2.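

For the compounds shown here, replacing 3,4,5-trimethoxyphenyl with 4-methoxyphenyl on a double-bonded chain carbon bound to a double-bonded chain carbon gives, in this assay, a number 21 percentage points lower from compound 2 to compound 4 (beyond the scatter) and so provides the first direct reading of a change at this place. The loss of growth inhibition at the concentration tested shows that the group at this position matters, and that the larger 3,4,5-trimethoxyphenyl is the better of the two here. Nothing available bears on the cause of this fall.

From the compounds shown here alone, it remains open whether the fall belongs to one particular methoxy group of those that leave or to all of them together. Also open, going by these compounds, is how an unsubstituted phenyl, or a phenyl carrying a hydroxyl or a dimethylamino group, would stand at this place.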